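A few compounds are considered here, and "the series" means these few. Any claim that something is new, unique, unknown or untested is made for them only; others in the source may bear on it.

Measured so far:
compound 1 `CCN1CCN(Cc2c(OC)cc(Oc3cccc(Nc4ccccc4)c3)cc2OC)CC1` gives > 20000 nM in a functional assay on SW-620 cells (Homo sapiens) for inhibition, read by MTT assay, with a stated time of 72 h; a lower number here means a stronger inhibitor, a higher number a weaker inhibitor
compound 2 `COc1ccc(CCCNCc2c(OC)cc(Oc3ccc(Nc4ccccc4)cc3)cc2OC)cc1` gives 14600 nM in this assay

The figure for compound 1 is a limit of the assay and not a number; where compound 1 stands in this assay can therefore only be said as a floor, its result sitting at the limit of > 20000 nM in this assay, at which 1 of the 2 values shown sits. Compound 2 returns a number in this assay, 14600 nM, and is the only measured point of the series that does so. Within the data shown here, no step between two measured compounds is available, so no measured change in this assay can yet be sized.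

Compound 3 `COc1cc(Oc2cccc(Nc3ccccc3)c2)cc(OC)c1CNCc1ccc(Br)cc1` remains to be measured in this assay. It differs from compound 1 by (4-bromobenzyl)amino in place of 4-ethylpiperazin-1-yl on a saturated chain carbon bound to an aromatic carbon. With only a limit for compound 1 and a single number for compound 2, the size of the step from compound 1 to compound 3 is an expectation and nothing more. A move toward stronger inhibition is expected, an at least 2.0-fold lower number from compound 1 to compound 3 (0.30 log units; that floor lies within the scatter), because compound 2 gives 14600 nM in this assay. Compound 3 is expected at about 10000 nM in this assay, estimated within 3000 nM to 30000 nM.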

Compound 3, half-maximal inhibitory concentration: 11200 nM
Estimate against measurement, compound 3: 1.1-fold (0.05 log units) below, within the range that was stated.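

With (4-bromobenzyl)amino in place of 4-ethylpiperazin-1-yl on a saturated chain carbon bound to an aromatic carbon, the series gains its first one-place change in this assay, and it reads as an at least 1.7-fold lower number from compound 1 to compound 3 (0.25 log units; that floor lies within the scatter). This place on the core of compound 1 can therefore return a number, with compound 3 giving 11200 nM in this assay. The result for compound 1 remains a limit of the assay, so the step is only a floor and its full size cannot be read: the limit of > 20000 nM in this assay, at which 1 of the 3 values shown sits.

The compounds shown leave open which part of (4-bromobenzyl)amino goes with the result: the bromine, the aromatic ring or the amine hydrogen. An unsubstituted benzylamino group, a 4-chlorobenzylamino group or a morpholin-4-yl ring at this same place on the core of compound 1 would separate these parts.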